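Styrenyl terpenoid series: methoxy to 3-fluorophenyl in SEM cytotoxicity

A few compounds are considered here, and "the series" means these few. Any claim that something is new, unique, unknown or untested is made for them only; others in the source may bear on it.

Measured so far:
compound 1, `C=C[C@@](C)(/C=C/c1ccc(OC)cc1)CCC=C(C)C`: > 36600 nM
compound 2, `C=C[C@@](C)(/C=C/c1ccc(O)cc1)CC/C=C/C(=O)OCC`: > 36600 nM

Both values are limits of the assay rather than numbers. In a functional assay on SEM cells (Homo sapiens) for cytotoxicity, with a stated time of 72 h (a higher number here means that more compound is needed for the effect, a lower number that less compound is needed), compound 1 reaches only the limit > 36600 nM. Compound 2 likewise gives only the limit > 36600 nM in this assay. Compound 1 therefore stands at the limit, as described by the limit of > 36600 nM in this assay, at which 2 of the 2 values shown sit, and nothing in the two values separates it from compound 2.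

Compound 3, `C=C[C@@](C)(/C=C/c1ccc(-c2cccc(F)c2)cc1)CCC=C(C)C`, is not yet measured. It differs from compound 1 as follows: 3-fluorophenyl in place of methoxy on an aromatic carbon.

Among the compounds with values here, no step between measured compounds exists to calibrate this change. With both known values at the limit, the expectation for compound 3 is no step beyond the scatter in this assay, with the possibility that a number appears at all. The step that the limit leaves unreadable from compound 1 to compound 3 is the estimated one. Compound 3 is expected at 40000 nM, within 8000 nM to 200000 nM.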

Compound 3, half-maximal effective concentration: > 36600 nM
Compound 3 ended at the assay's limit (the forecaster's own chance of this, stated with the estimate: 70%); the middle value is on the limit's open side.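

No step can be read from compound 1 to compound 3 in this assay, because both stand at the limit of the assay: the limit of > 36600 nM in this assay, at which 3 of the 3 values shown sit.

The compounds shown leave open whether any change on the shared core yields a measurable value in this assay.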